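From compound 2 to compound 3: hydroxy for fluoro

The source may hold more compounds than are shown below. What is called first, only, known or untested is meant among the compounds shown, and "the series" means these compounds.

In an ADME assay on HepG2 cells (Homo sapiens) for cytotoxicity, with a stated time of 72 h (on this read-out higher numbers stand for an effect only at larger amounts of compound and lower numbers for an effect already at smaller amounts), compound 1 (`Cc1cc(NC(=O)Nc2ccc(F)c(F)c2)c2ccccc2n1`) gives 21000 nM as a measured number. Compound 2 (`Cc1cc(NC(=O)Nc2ccc(F)cc2)c2ccccc2n1`) gives > 25000 nM as a limit of the assay and not a number. Compound 3 (`Cc1cc(NC(=O)Nc2ccc(O)cc2)c2ccccc2n1`) differs from compound 2 by hydroxy in place of fluoro on an aromatic carbon in one place, with hydroxy in place of fluoro on an aromatic carbon, para to a large group. For the measured compounds named here, the only measured step (an at least 1.1-fold higher number from compound 1 to compound 2 (0.07 log units; that floor lies within the scatter)) is hydrogen in place of fluoro on an aromatic carbon, and it bears on this change only loosely. In this assay no change beyond the scatter is expected (a number no higher from compound 2 to compound 3 (the limit leaves the size open)) and no direction is favoured. Compound 3 is expected at 25000 nM within an estimated range (12000 nM to 40000 nM).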

Compound 3, half-maximal effective concentration: > 25000 nM
Compound 3 ended at the assay's limit; the forecaster's own chance of this, stated with the estimate: 60%; the middle value lies on the limit itself.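

For the compounds shown here, no step from compound 2 to compound 3 can be read in this assay, because both compounds stand at a limit of the assay and neither gives a number: the limit of > 25000 nM in this assay, at which 2 of the 3 values shown sit. The compounds shown leave open whether 4-fluorophenyl and 4-hydroxyphenyl differ at all on this read-out.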